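Benzyloxy in place of methyl: stability notes

This account rests on a few compounds, and the source may have more. Where it says the series, first, only, none or still open, it means among the compounds named here.

Values in an ADME assay on microsomes from liver (Homo sapiens), read by LC-MS, using NADPH, with a stated time of 10 min, tested at 0.5 uM (on this read-out higher numbers stand for a more stable compound and lower numbers for a less stable compound), so far
Compound 1 `Cc1nc2cc(-c3ccccc3)nn2c(N2CCC(C)(C)CC2)c1C(OC(C)(C)C)C(=O)O` gives 100%
Compound 2 `Cc1ccc(-c2cc3nc(C)c(C(OC(C)(C)C)C(=O)O)c(-c4cc(F)c5c(c4C)CCCO5)n3n2)cc1` gives 95%

Compound 2 stands within the scatter of compound 1 on these numbers, so the two values set no order between them. Within the data shown here, the core of compound 1 differs from that of compound 2, and no step between measured compounds is available as a guide. Compound 3 `Cc1nc2cc(-c3ccc(OCc4ccccc4)cc3)nn2c(-c2cc(F)c3c(c2C)CCCO3)c1C(OC(C)(C)C)C(=O)O` follows from compound 2 by benzyloxy in place of methyl on an aromatic carbon, para to a large group (benzyloxy in place of methyl on an aromatic carbon). In this assay a moderate downward step is expected, though one within the scatter cannot be excluded, and this expectation rests on the structural change alone. The expected move is a number 10 percentage points lower from compound 2 to compound 3 (within the scatter) on this estimate. Compound 3 is estimated at 85% with an expected range from 60% to 100% in this read-out.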

Compound 3, percent of the compound remaining: 84%
The estimate for compound 3 lay 1 percentage points above the measured number; low and high end bracket the measured number.
By their numbers in this assay, from the lowest: compound 3; then compounds 2 and 1 (each within the scatter of the next).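

In this assay, among these compounds, the replacement of methyl by benzyloxy on an aromatic carbon, para to a large group, gives the only readable step so far: a number 11 percentage points lower from compound 2 to compound 3 (beyond the scatter). This position therefore accepts a group of 8 heavy atoms, including a six-membered aromatic ring of carbon only, at a modest cost on this read-out, with compound 3 still at 84%. Nothing at hand bears on the reason for this step.

The compounds shown do not separate the contributions of the oxygen and the added ring; methoxy or benzyl at the same place would bear on that question. Going by these compounds, how an amine-bearing chain at this position would read in this assay also remains open.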